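The source may hold more compounds than are shown below. What is called first, only, known or untested is meant among the compounds shown, and "the series" means these compounds.

Series notes, values in a functional assay on HepG2 cells (Homo sapiens) for cytotoxicity, with a stated time of 72 h; a higher number here means that more compound is needed for the effect, a lower number that less compound is needed:

- compound 1 `C=C[C@@](C)(/C=C/c1ccc(OS(=O)(=O)C(F)(F)F)cc1)CCC=C(C)C`: > 52000 nM (a limit)
- compound 2 `C=C[C@@](C)(/C=C/c1ccc(Nc2ccccc2)cc1)CCC=C(C)C`: > 52000 nM (a limit)
- compound 3 `C=C[C@@](C)(/C=C/c1ccc(Nc2cc(F)cc(F)c2)cc1)CCC=C(C)C`: > 52000 nM (a limit)

Compound 3 has no numerical value in this assay, only a limit, and compound 1 and compound 2 give no number either. All three share one limit: the limit of > 52000 nM in this assay, at which 3 of the 3 values shown sit.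

Compound 4 `C=C[C@@](C)(/C=C/c1ccc(Nc2ccc(Cl)c(F)c2)cc1)CCC=C(C)C` carries 4-chloro-3-fluorophenyl in place of 3,5-difluorophenyl on a nitrogen on an aromatic ring.

The closest measured comparison is the change on the same nitrogen, a step that the two limits leave unreadable from compound 2 to compound 3. The changes on the aromatic carbon, a step that the two limits leave unreadable from compound 1 to compound 2 and a step that the two limits leave unreadable from compound 1 to compound 3, bear on it less directly and are equally unreadable. For the measured compounds named here, no measured step therefore gives a size or a direction for this change, and no shift beyond the scatter is expected in this assay. The expected outcome is another limit reading, with a step that the limit leaves unreadable from compound 3 to compound 4 as the estimated step. For compound 4 the estimate is 60000 nM, with an expected range from 30000 nM to 120000 nM.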

Compound 4, half-maximal effective concentration: > 52000 nM
Compound 4: only a limit was reported; the forecaster's own chance of this, stated with the estimate: 85%; the middle value does not contradict the limit.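

Compound 4 gives only a limit in this assay, so none of its steps from compound 1, compound 2 or compound 3 can be read: the limit of > 52000 nM in this assay, at which 4 of the 4 values shown sit.

The compounds shown leave open whether any group on the nitrogen gives a numerical value in this assay.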